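From 4-methoxyphenyl to 3-methoxyphenyl on a carbonyl carbon

This account rests on a few compounds, and the source may have more. Where it says the series, first, only, none or still open, it means among the compounds named here.

Measured in an ADME assay on cells (Lymphocyte, Homo sapiens) for cytotoxicity, read by MTT assay, with a stated time of 48 h; a higher number here means a weaker inhibitor, a lower number a stronger inhibitor:
compound 1 `COC(=O)/C(=C\c1ccc(O)cc1)Sc1ccnc2cc(Cl)ccc12`: 33700 nM
compound 2 `COC(=O)/C(=C\c1ccc(OC(=O)c2ccc(OC)cc2)cc1)Sc1ccnc2cc(Cl)ccc12`: 63500 nM

For the measured compounds named here, on these numbers, compound 2 cannot be told apart from the only other measured compound. Compound 3 `COC(=O)/C(=C\c1ccc(OC(=O)c2cccc(OC)c2)cc1)Sc1ccnc2cc(Cl)ccc12` has the same atoms as compound 2, joined differently: 3-methoxyphenyl in place of 4-methoxyphenyl on a carbonyl carbon. Here 3-methoxyphenyl stands in place of 4-methoxyphenyl on a carbonyl carbon. Going by the values given here, no measured step covers this exact change. The closest evidence is the step that put (4-methoxyphenyl)carbonyl in place of hydrogen on an oxygen on an aromatic ring, which gave a 1.9-fold higher number from compound 1 to compound 2 (0.28 log units; within the scatter). Among the compounds with values here, with only this one step to go on, no shift beyond the scatter is expected in this assay, and the direction cannot be told. The expected step is a 1.1-fold lower number from compound 2 to compound 3 (0.02 log units; within the scatter). For compound 3 the estimated value is 60000 nM, with an expected range of 30000 nM to 120000 nM.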

Compound 3, half-maximal inhibitory concentration: > 100000 nM
Compound 3: only a limit was reported; the forecaster's own chance of this, stated with the estimate: 15%; middle value at least 1.6-fold (0.22 log units) from the limit.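

In this assay compound 3 sits at a limit of the assay and has no exact number: the limit of > 100000 nM in this assay, at which 1 of the 3 values shown sits. The change of 4-methoxyphenyl to 3-methoxyphenyl gives an at least 1.5-fold higher number from compound 2 to compound 3 (0.19 log units; that floor lies within the scatter), so the limit does not show that these two compounds differ. Against the free hydroxyl of compound 1, however, the new ester gives an at least 2.9-fold higher number from compound 1 to compound 3 (0.47 log units; beyond the scatter), the first step shown to clear the scatter, whereas the step from compound 1 to compound 2 stayed within it.

Still open, on these data alone, is how far compound 3 lies past the limit, and so whether the position of the methoxy group matters at all in this assay. Also open, as far as these compounds go, is how an amine or a carboxylic acid in place of that methoxy group would read.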